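A few compounds are considered here, and "the series" means these few. Any claim that something is new, unique, unknown or untested is made for them only; others in the source may bear on it.

Four compounds built on one five-membered aromatic ring with two nitrogen atoms, each carrying a 6-carboxy-3,5-dihydroxyhexyl chain, were examined in an assay on microsomes from liver for inhibition of 3-hydroxy-3-methylglutaryl-coenzyme A reductase (Rattus norvegicus); a higher number here means a weaker inhibitor, a lower number a stronger inhibitor. Compound 1, `O=C(O)C[C@H](O)C[C@H](O)CCn1c(C(F)(F)F)nc(-c2ccc(C(F)(F)F)cc2)c1-c1ccc(F)cc1`, gives 200 nM in this assay. Compound 2, `Cc1cc(C)cc(-c2nc(C(F)(F)F)n(CC[C@@H](O)C[C@@H](O)CC(=O)O)c2-c2ccc(F)cc2)c1`, gives 24 nM in this assay. For the measured compounds named here, the single change between them is 3,5-dimethylphenyl in place of 4-(trifluoromethyl)phenyl on an aromatic carbon, and it produced an 8.3-fold lower number from compound 1 to compound 2 (0.92 log units; beyond the scatter).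

Compound 3, `O=C(O)C[C@H](O)C[C@H](O)CCn1c(C(F)(F)F)nc(-c2ccc(F)cc2)c1-c1ccc(C(F)(F)F)cc1`, is built from the same atoms as compound 1, joined differently; the difference between the two cores is not broken down here. For compound 3 this assay reports only a limit, > 1000 nM, which is the limit of > 1000 nM in this assay, at which 1 of the 3 values shown sits.

Compound 4, `Cc1cc(C)cc(-c2c(-c3ccc(F)cc3)nc(C(F)(F)F)n2CC[C@@H](O)C[C@@H](O)CC(=O)O)c1`, has not yet been measured. It differs from compound 3 by 3,5-dimethylphenyl in place of 4-(trifluoromethyl)phenyl on an aromatic carbon. Going by the values given here, in compound 1 the changed aromatic carbon is two ring bonds from the ring atom that bears the 6-carboxy-3,5-dihydroxyhexyl group, whereas in compound 3 it is next to the ring atom that bears that group, so the change from compound 3 to compound 4 is the same kind of change as the one from compound 1 to compound 2, not the same change.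

Taking the step seen from compound 1 to compound 2 as the only guide, compound 4 is expected to show an at least 2.5-fold lower number from compound 3 to compound 4 (0.39 log units; beyond the scatter) in this assay. Since compound 3 gave only a limit, the starting point is uncertain, and the estimate for compound 4 is accordingly wide: 400 nM, between 100 nM and 2000 nM.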

Compound 4, half-maximal inhibitory concentration: 38 nM
Compound 4: the middle estimate sits 11-fold (1.02 log units) above what was measured, and the stated range ends above it.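

In this assay, putting 3,5-dimethylphenyl in place of 4-(trifluoromethyl)phenyl gave an at least 26-fold lower number from compound 3 to compound 4 (1.42 log units; beyond the scatter), so the change lowered the number on the core of compound 3 as it had on the core of compound 1. The direction carried over between these two cores, but the size of the step did not stay the same: the same change on two cores in this assay, an 8.3-fold lower number (0.92 log units; beyond the scatter) from compound 1 to compound 2 and an at least 26-fold lower number (1.42 log units; beyond the scatter) from compound 3 to compound 4, at least 3.1-fold (0.49 log units) apart, beyond the scatter of two such steps. As far as these compounds go, the second step rests on a limit for compound 3, so its true size and its full distance from the first step remain unknown, and two pairs of compounds give no rule for any other core: the limit of > 1000 nM in this assay, at which 1 of the 4 values shown sits.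

The compounds shown leave open whether both methyl groups of the 3,5-dimethylphenyl group are needed, since a 3-methylphenyl group, a 4-methylphenyl group or an unsubstituted phenyl group does not appear among them at this place. They also leave open whether the same change would hold up with a methyl group, an isopropyl group or an amine in place of the trifluoromethyl group on the ring, or with a longer chain in place of the 6-carboxy-3,5-dihydroxyhexyl group.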